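This account rests on a few compounds, and the source may have more. Where it says the series, first, only, none or still open, it means among the compounds named here.

Measured compounds:
compound 1, `NC(=O)c1c(NC(=O)c2ccccc2Cl)sc2c1CCN(Cc1ccc(Cl)cc1Cl)C2`, 8010 nM
compound 2, `NC(=O)c1c(NC(=O)c2ccccc2F)sc2c1CCN(Cc1ccc(Cl)cc1Cl)C2`, 13100 nM

In a functional assay on HL-60 cells (Homo sapiens) for antiproliferative activity, with a stated time of 24 h (on this read-out higher numbers stand for weaker inhibition and lower numbers for stronger inhibition), compound 1 gives the lowest of the two numbers, and the nearest is compound 2, separated by a 1.6-fold higher number from compound 1 to compound 2 (0.21 log units; within the scatter). Compound 3, `COc1ccc(NC(=S)N2CCc3c(sc(NC(=O)c4ccccc4Cl)c3C(N)=O)C2)cc1`, has not been measured. It differs from compound 1 by a group of 11 heavy atoms (8 carbon, 1 nitrogen, 1 oxygen, 1 sulfur; one six-membered aromatic ring of carbon only) in place of a group of 9 heavy atoms (7 carbon, 2 chlorine; one six-membered aromatic ring of carbon only), on an amine nitrogen in a ring. Among the compounds with values here, the only measured step, the move from compound 1 to compound 2, touches the aromatic carbon of the benzamide and leaves the group on the amine nitrogen in a ring unchanged, so it says nothing about what the exchange at that nitrogen will do. Nothing here shows how the new group behaves. Compound 3 is therefore expected to stay near compound 1, with a step of a 1.0-fold lower number from compound 1 to compound 3 (0.00 log units; within the scatter), and its estimated value in this assay is 8000 nM, within a wide range from 2000 nM to 32000 nM.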

Compound 3, half-maximal inhibitory concentration: 15700 nM
Compound 3: middle estimate off by 2.0-fold (0.29 log units), on the low side; the range from low to high includes it.
By their numbers in this assay, from the lowest: compounds 1, 2 and 3 (each within the scatter of the next).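

Compounds 1 and 2 share the 2,4-dichlorobenzyl group on the amine nitrogen in a ring, so only compound 3 tests an exchange at this place. In this assay, the entering group, with its double bond outside aromatic rings, hydrogen-bond donor and hydrogen-bond acceptors, gives a 2.0-fold higher number from compound 1 to compound 3 (0.29 log units; within the scatter). This position therefore takes that group in place of 2,4-dichlorobenzyl with no difference beyond the scatter, and no measurement at hand bears on the reason for this result.

The compounds shown leave open how a urea carrying oxygen in place of the sulfur, or a plain benzyl group without chlorine, would read at this nitrogen. They also leave open whether any group here can move the number beyond the scatter.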